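This account rests on a few compounds, and the source may have more. Where it says the series, first, only, none or still open, it means among the compounds named here.

Compound 1 `CCOC(=O)c1c(F)c(N)c2c(=O)cc(-c3ccc(N)c(F)c3)oc2c1F` gives a limit of > 100000 nM in a functional assay on HeLa cells (Homo sapiens) for cytotoxicity, read by neutral red uptake, with a stated time of 3 days; on this read-out lower numbers stand for stronger inhibition and higher numbers for weaker inhibition.
Compound 2 `CCCOCc1c(F)c(N)c2c(=O)cc(-c3ccc(N)c(F)c3)oc2c1F` gives 78000 nM in this assay.
Compound 3 `CN(C)CCCOCc1c(F)c(N)c2c(=O)cc(-c3ccc(N)c(F)c3)oc2c1F` gives 12000 nM in this assay.

Compound 3 holds the lowest of the two numbers; compound 2 is nearest, by a 6.5-fold lower number from compound 2 to compound 3 (0.81 log units; beyond the scatter), and one value is only a limit (the limit of > 100000 nM in this assay, at which 1 of the 3 values shown sits). Compound 4 `NCc1c(F)c(N)c2c(=O)cc(-c3ccc(N)c(F)c3)oc2c1F` differs from compound 3 by amino in place of 3-(dimethylamino)propoxy on a saturated chain carbon bound to an aromatic carbon. Among the compounds with values here, no measured step covers this exact change. The steps that touch the same carbon are an at least 8.3-fold lower number from compound 1 to compound 3 (0.92 log units; beyond the scatter) and a 6.5-fold lower number from compound 2 to compound 3 (0.81 log units; beyond the scatter). Compound 4 keeps a basic nitrogen but loses the chain, so a step in this assay toward a higher number is expected, but smaller than the step between compound 2 and compound 3. For compound 4 the expected step is a 2.1-fold higher number from compound 3 to compound 4 (0.32 log units; beyond the scatter), giving an estimate of 25000 nM with a range of 6000 nM to 100000 nM.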

Compound 4, half-maximal inhibitory concentration: 8800 nM
The estimate for compound 4 lay 2.8-fold (0.45 log units) above the measured number; measured number inside the range.
By their numbers in this assay, from the lowest: compounds 4 and 3 (each within the scatter of the next); then compound 2. At a limit, above all of these: compound 1.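

On the saturated chain carbon bound to an aromatic carbon, amino in place of the whole 3-(dimethylamino)propoxy group gives a 1.4-fold lower number from compound 3 to compound 4 (0.13 log units; within the scatter), so the long chain is not needed to hold the number of compound 3. Amino in place of propoxy gives an 8.9-fold lower number from compound 2 to compound 4 (0.95 log units; beyond the scatter), so a nitrogen at the end of an ether chain is not the only form of this change that lowers the number. Aminomethyl in place of ethoxycarbonyl gives an at least 11-fold lower number from compound 1 to compound 4 (1.05 log units; beyond the scatter), a step that rests on a limit in this assay: the limit of > 100000 nM in this assay, at which 1 of the 4 values shown sits.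

As far as these compounds go, whether dimethylamino set directly on that carbon reads like amino remains open. So does the outcome for a hydroxyl group or a carboxylic acid there.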